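The source may report more compounds than this note shows. Statements on the series, on what has been measured and on what is new or still open speak of the compounds shown alone.

Measured so far in an ADME assay on Vero cells (Chlorocebus sabaeus) for cytotoxicity, read by MTT assay, with a stated time of 48 h; a lower number here means that less compound is tolerated, a higher number that more compound is tolerated:
- compound 1, `C=C1CC[C@@H]2[C@](C)(CO)[C@H](O)CC[C@@]2(C)[C@@H]1C/C=C1/C(=O)OC[C@H]1Oc1c(Cl)cc(Cl)c2cccnc12`, gives 82500 nM
- compound 2, `C=C1CC[C@@H]2[C@](C)(CO)[C@H](O)CC[C@@]2(C)[C@@H]1C/C=C1/C(=O)OC[C@@H]1Oc1cccc2ccc(C)nc12`, gives 99800 nM
- compound 3, `C=C1CC[C@@H]2[C@](C)(CO)[C@H](O)CC[C@@]2(C)[C@@H]1C/C=C1/C(=O)OC[C@@H]1Oc1c(Cl)cc(Cl)c2cccnc12`, gives > 100000 nM; this is a limit of this assay, not a number.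

Compound 2 holds the higher of the two numbers; its nearest neighbour is compound 1, and the gap between them is within the scatter, so no order can be read between the two.

Compound 4, `C=C1CC[C@@H]2[C@](C)(CO)[C@H](O)CC[C@@]2(C)[C@@H]1C/C=C1/C(=O)OC[C@H]1Oc1cccc2ccc(C)nc12`, has not yet been measured. It differs from compound 2 as follows: the two compounds have the same atoms and bonds and differ only in configuration as drawn: 1 of 7 stereo elements differ; a stereocentre at a saturated ring carbon is drawn R in compound 2 and S in compound 4. Within the data shown here, two measured steps bear on this. The step from compound 1 to compound 3 is the same kind of change, and gave an at least 1.2-fold higher number from compound 1 to compound 3 (0.08 log units; that floor lies within the scatter); it rests on the fact that compounds 1 and 3 differ only in the configuration as drawn and on (the limit of > 100000 nM in this assay, at which 1 of the 3 values shown sits), which leaves its size open. The step from compound 2 to compound 3 gave a number no lower from compound 2 to compound 3 (the limit leaves the size open). Neither shows a shift beyond the scatter, so in this assay a step of about a 1.2-fold lower number from compound 2 to compound 4 (0.07 log units; within the scatter) is expected, with no direction that can be trusted.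

Compound 4 is therefore estimated at 85000 nM, within a range from 40000 nM to 150000 nM.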

Compound 4, half-maximal cytotoxic concentration: 61400 nM
For compound 4 the middle estimate is 1.4-fold (0.14 log units) above the measured one, and the stated range covers the measured number.
By their numbers in this assay, from the lowest: compounds 4, 1 and 2 (each within the scatter of the next). At a limit, above all of these: compound 3.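

With two readable numbers at this stereocentre, the change from R to S in this assay now has a size: a 1.6-fold lower number from compound 2 to compound 4 (0.21 log units; within the scatter). Among these compounds, the exchange of the quinoline groups also has a readable size for the first time, with 2-methylquinolin-8-yl in place of 5,7-dichloroquinolin-8-yl on the S configuration: a 1.3-fold lower number from compound 1 to compound 4 (0.13 log units; within the scatter). Compound 3 gives > 100000 nM, which is a limit of the assay and not a number, so the steps that end at compound 3 still have no readable size.

From the compounds shown here alone, how far compound 3 really stands from the other compounds therefore stays open. So does whether a different group on the oxygen, such as a quinolin-8-yl carrying an amine or a carboxylic acid, would shift the number in this assay beyond the scatter.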